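The source may report more compounds than this note shows. Statements on the series, on what has been measured and on what is new or still open speak of the compounds shown alone.

Measured so far in a functional assay on HepG2 cells (Homo sapiens) for antiproliferative activity, read by MTT assay, with a stated time of 48 h; a lower number here means a stronger inhibitor of growth, a higher number a weaker inhibitor of growth:

- compound 1 `Cc1ccc(-c2cnc(N(Cc3ccccc3)Cc3ccc(C(=O)NO)cc3)s2)cc1`: 34000 nM
- compound 2 `Cc1ccc(-c2cnc(N(Cc3ccc(C(=O)NO)cc3)CC(C)C)s2)cc1`: 7420 nM
- compound 3 `CCCCCCCCN(Cc1ccc(C(=O)NO)cc1)c1ncc(-c2ccc(C)cc2)s1`: not yet measured

Compound 1 stands at the highest of the two numbers recorded in this assay, and its nearest neighbour is compound 2, which lies lower by a step that is beyond the scatter.

Compound 3 differs from compound 1 in one place: heptyl in place of phenyl on a saturated chain carbon bound to a nitrogen on an aromatic ring. Among the compounds with values here, the only measured step that bears on this change is a 4.6-fold lower number from compound 1 to compound 2 (0.66 log units; beyond the scatter), where an isopropyl took the place of the phenyl at the same position and the number fell by a modest amount. The change to compound 3 goes the same way, swapping the phenyl for a saturated chain, here a longer one, so a step in the same direction is expected in this assay, of roughly the same size or somewhat larger, and in any case beyond the scatter.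

Compound 3 is therefore expected to give about 5000 nM, within a range of 1500 nM to 15000 nM, which means an expected step of a 6.8-fold lower number from compound 1 to compound 3 (0.83 log units; beyond the scatter).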

Compound 3, concentration for 50% growth inhibition: 8760 nM
Compound 3: the middle estimate sits 1.8-fold (0.24 log units) below what was measured; measured number inside the range.
By their numbers in this assay, from the lowest: compounds 2 and 3 (each within the scatter of the next); then compound 1.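

In this assay, heptyl in place of phenyl on a saturated chain carbon bound to a nitrogen on an aromatic ring gives a 3.9-fold lower number from compound 1 to compound 3 (0.59 log units; beyond the scatter) and so shows that the lower number seen with isopropyl at this position is not confined to that one group: both saturated groups shown here stand lower than phenyl, and none of the three compounds goes against this. Heptyl in place of isopropyl gives a 1.2-fold higher number from compound 2 to compound 3 (0.07 log units; within the scatter) and so adds something the first pair could not show, namely that across these two chains the difference in size does not separate the numbers beyond the scatter. Nothing measured on these compounds offers an explanation for either step.

Three compounds cannot tell whether the step from compound 1 follows from losing the aromatic ring or from some other difference between the groups, and a saturated ring such as cyclohexyl at the same position would help to separate these readings. On these data alone, it also remains open how a shorter chain such as ethyl, or a chain ending in an amine or a carboxylic acid, would stand in this assay.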